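Working notes: from compound 2 to compound 4

The compounds below may be only part of what the source reports. "The series", "measured", "known", "first", "only" and "open" are said of these compounds alone.

Readings in a physicochemical assay for solubility (on this read-out lower numbers stand for lower solubility and higher numbers for higher solubility), are limits only:
- compound 1 (`O=C(O)c1ccc(C(=O)/C(=C\c2ccc([N+](=O)[O-])cc2F)SCc2ccc(Br)cc2)cc1`) has the limit < 1000 ug/mL
- compound 2 (`O=C(O)c1ccc(C(=O)/C(=C\c2ccc(F)cc2[N+](=O)[O-])SCc2ccc(Br)cc2)cc1`) has the limit < 1000 ug/mL
- compound 3 (`O=C(O)c1ccc(C(=O)/C(=C\c2ccc(F)c([N+](=O)[O-])c2)SCc2ccccc2)cc1`) has the limit < 1000 ug/mL

Compound 2 therefore stands at a limit and offers no number to measure a step from. The structural change to compound 4 (`O=C(O)c1ccc(C(=O)/C(=C\c2ccc(O)c(Br)c2)SCc2ccc(Br)cc2)cc1`) brings 3-bromo-4-hydroxyphenyl in place of 4-fluoro-2-nitrophenyl on a double-bonded chain carbon bound to a double-bonded chain carbon.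

For the measured compounds named here, the only measured step at this place is a step that the two limits leave unreadable from compound 1 to compound 2 and it has no readable size. The whole record is the limit of < 1000 ug/mL in this assay, at which 3 of the 3 values shown sit, and it gives no direction for this change. No step beyond the scatter is therefore expected in this assay on these data. The estimated step is a step that the limit leaves unreadable from compound 2 to compound 4 and it carries little weight. For compound 4 the estimate is 300 ug/mL with an expected range from 50 ug/mL to 1000 ug/mL and another report as a limit is the likeliest outcome.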

Compound 4, solubility: < 1000 ug/mL
Compound 4 gave a limit, no number; the forecaster's own chance of this, stated with the estimate: 85%; the middle value lies beyond the limit too.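

In this assay compound 4 gives < 1000 ug/mL, which is a limit and not a number, so the steps to it from compound 1 and compound 2 cannot be read. Whether exchanging these groups moves the read-out at all stays open, with the whole record at one value: the limit of < 1000 ug/mL in this assay, at which 4 of the 4 values shown sit.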